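Benzyl ether in place of the chloropyridyl ether

This account rests on a few compounds, and the source may have more. Where it says the series, first, only, none or still open, it means among the compounds named here.

Measured so far:
compound 1, `O=C1NC(=O)C(Cc2ccc(Oc3ccc(C(F)(F)F)cn3)cc2)S1`, 558 nM
compound 2, `O=C1NC(=O)C(Cc2ccc(Oc3ccc(Cl)cn3)cc2)S1`, 1870 nM
compound 3, `O=C1NC(=O)C(Cc2ccc(Oc3ncc(Cl)cc3Cl)cc2)S1`, 90 nM

In a functional assay for agonist activity at Free fatty acid receptor 1 (Homo sapiens), read by FLIPR, in the presence of a further agent that is not named here (a lower number here means that less compound is needed, a higher number that more compound is needed for the effect), compound 2 gives 1870 nM, the highest of the three numbers. Its nearest neighbour is compound 1 with 558 nM, the step being a 3.4-fold higher number from compound 1 to compound 2 (0.53 log units; beyond the scatter). Furthest away is compound 3 with 90 nM, reached through a 21-fold lower number from compound 2 to compound 3 (1.32 log units; beyond the scatter).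

Compound 4, `O=C1NC(=O)C(Cc2ccc(OCc3ccccc3)cc2)S1`, is not yet measured. It differs from compound 2 in one place: benzyl in place of 5-chloropyridin-2-yl on an oxygen on an aromatic ring. Neither measured step covers this change; both replace one group on the aromatic carbon of the same ring while compound 4 exchanges the whole ring and adds a methylene. The two steps do show that the ring part shifts the number strongly in either direction, so a step beyond the scatter is expected here too. Compound 4 loses the chloro whose introduction gave the large step to compound 3, so a higher number is expected, estimated as a 1.9-fold higher number from compound 2 to compound 4 (0.27 log units; within the scatter). For compound 4 the expected value is 3500 nM, with a range from 900 nM to 14000 nM.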

Compound 4, half-maximal effective concentration: 6180 nM
Beside the measured number, compound 4's estimate is 1.8-fold (0.25 log units) below it; low and high end bracket the measured number.
By their numbers in this assay, from the lowest: compound 3; then compound 1; then compound 2; then compound 4.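

In this assay, among these compounds, the earlier steps changed only single groups on the ring, whereas this one shows that the whole 5-chloropyridin-2-yl on the oxygen can give way to benzyl, with the same count of heavy atoms, and still leave a measurable response, at a modest cost: a 3.3-fold higher number from compound 2 to compound 4 (0.52 log units; beyond the scatter). This single change removes the ring nitrogen and the chloro and adds a methylene, so the step cannot be divided among these parts. No measurement here explains the rise in the number.

The compounds shown leave open whether a plain phenyl on the oxygen would separate the effect of the methylene from that of the ring. They also leave open how chloro, trifluoromethyl or a carboxylic acid on the benzyl ring, or a longer chain in its place, would shift the number.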